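The source may report more compounds than this note shows. Statements on the series, on what has been measured and on what is new or still open speak of the compounds shown alone.

Compound 1 `COC(=O)/C=C/c1cccc(N(Cc2ccc(/C=C/c3cccc(C(F)(F)F)c3)cc2)C(=O)C(C)C)c1` gives 267 nM in an assay on isolated protein with Bile acid receptor (Homo sapiens) as the target; on this read-out lower numbers stand for an effect already at smaller amounts and higher numbers for an effect only at larger amounts of compound. Compound 2 `COC(=O)/C=C/c1cccc(N(Cc2ccc(/C=C/c3c(C)cc(C)cc3C)cc2)C(=O)C(C)C)c1` gives 149 nM. Compound 3 `COC(=O)/C=C/c1cccc(N(Cc2ccc(/C=C/c3ccccn3)cc2)C(=O)C(C)C)c1` gives 310 nM.

Compound 3 sits at the high end of the numbers shown: its gap to compound 1 is within the scatter, while the step of a 2.1-fold higher number from compound 2 to compound 3 (0.32 log units; beyond the scatter) lies beyond it. Compound 4 `COC(=O)/C=C/c1cccc(N(Cc2ccc(-c3ccc(SC)cc3)cc2)C(=O)C(C)C)c1` differs from compound 3 by 4-(methylsulfanyl)phenyl in place of 2-(pyridin-2-yl)ethenyl on an aromatic carbon. The measured steps all exchange only the ring bound to the double-bonded chain carbon and keep the ethenyl chain: a 1.8-fold lower number from compound 1 to compound 2 (0.25 log units; within the scatter) and a 1.2-fold higher number from compound 1 to compound 3 (0.06 log units; within the scatter) were both small. For the measured compounds named here, no measured step removes the chain itself, so they bear on this change only loosely. The change is therefore expected to give a 1.1-fold higher number from compound 3 to compound 4 (0.05 log units; within the scatter) in this assay, with wide uncertainty. Compound 4 is estimated at 350 nM, between 120 nM and 1000 nM.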

Compound 4, half-maximal effective concentration: 51 nM
For compound 4 the middle estimate is 6.9-fold (0.84 log units) above the measured one; measured number outside the range, below it.
By their numbers in this assay, from the lowest: compound 4; then compounds 2, 1 and 3 (each within the scatter of the next, the first and the last beyond it).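

In this assay, putting 4-(methylsulfanyl)phenyl on this aromatic carbon in place of the whole ethenyl-linked group gives larger steps than any exchange of the ring on the chain (a 6.1-fold lower number from compound 3 to compound 4 (0.78 log units; beyond the scatter); a 5.2-fold lower number from compound 1 to compound 4 (0.72 log units; beyond the scatter); a 2.9-fold lower number from compound 2 to compound 4 (0.47 log units; beyond the scatter)). All three lie beyond the scatter, so this position accepts the loss of the double bond outside aromatic rings and the number still falls. No evidence at hand accounts for this drop.

The compounds shown do not separate the loss of the ethenyl chain from the entry of the methylsulfanyl group. Going by these compounds, how an amine or a carboxylic acid in place of methylsulfanyl would read also remains open.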